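The source may hold more compounds than are shown below. What is called first, only, known or untested is meant among the compounds shown, and "the series" means these compounds.

Measured in a functional assay on the whole organism with Rattus norvegicus as the target; a higher number here means that more compound is needed for the effect, a lower number that less compound is needed:
Compound 1 `CCN(CCNC(=O)c1cc(Cl)c(N)cc1OC)Cc1cccc(Cl)c1`: 0.58 mg/kg
Compound 2 `COc1cc(N)c(Cl)cc1C(=O)NCCN(C)Cc1ccccc1C`: 2 mg/kg
Compound 3 `CCNc1cc(OC)c(C(=O)NC2CCN(Cc3ccccc3)C2)cc1Cl`: 0.1 mg/kg

Of these three, compound 3 has the lowest number, so it needs the least compound for the effect. Compound 1 and compound 2 both lie above it, beyond the scatter.

Compound 4 `COc1cc(N(C)C(C)=O)c(Cl)cc1C(=O)NC1CCN(Cc2ccccc2)C1` keeps the rest of compound 3 but carries acetyl(methyl)amino in place of ethylamino on an aromatic carbon. For the measured compounds named here, no measured pair shows this kind of change, so the expectation is a judgement. Compound 3 already stands lowest at 0.1 mg/kg, and a swap of this size seems more likely to raise the number than to lower it. A rise beyond the scatter is expected in this assay. The estimated change is a 20-fold higher number from compound 3 to compound 4 (1.30 log units; beyond the scatter). For compound 4 the estimate is 2 mg/kg, with an expected range from 0.4 mg/kg to 10 mg/kg.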

Compound 4, dose for half-maximal effect: > 30 mg/kg
Compound 4 was reported as a limit; the forecaster's own chance of this, stated with the estimate: 15%; middle value at least 15-fold (1.17 log units) from the limit.
By their numbers in this assay, from the lowest: compound 3; then compound 1; then compound 2. At a limit, above all of these: compound 4.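

In this assay, this aromatic carbon proves far from indifferent to its substituent: acetyl(methyl)amino in place of ethylamino gives an at least 300-fold higher number from compound 3 to compound 4 (2.47 log units; beyond the scatter). From the compounds shown here alone, compound 4 gives > 30 mg/kg, which is a limit of the assay and not a number, so the true size of the step stays unknown. The swap also replaces a group with a hydrogen-bond donor by one with none, but this single step cannot separate that difference from the added atoms. Acetylamino and dimethylamino on this carbon remain open. Either could help show whether the acetyl or the methyl on the nitrogen matters more.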